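Three Anilides Measured, a Third Methoxy Still Untested

The source may hold more compounds than are shown below. What is called first, only, known or untested is meant among the compounds shown, and "the series" means these compounds.

The measured compounds and their readings in a functional assay on the whole organism (strain albino) for inhibition, with Rattus norvegicus as the target, read by paw edema, with stated times of 30 min and 3 h, at a dose of 0.28 mmol/kg by the oral route (a lower number here means less inhibition, a higher number more inhibition at the dose given (going by the name of the read-out)), are:
compound 1, `C=CCn1c(SCC(=O)Nc2ccc(C(C)=O)cc2)nnc1-c1ccccc1`, which gives 54%;
compound 2, `C=CCn1c(SCC(=O)Nc2ccc(/C(C)=N/O)cc2)nnc1-c1ccc(OC)c(OC)c1`, which gives 70%;
compound 3, `C=CCn1c(SCC(=O)Nc2ccc(C(C)=O)cc2)nnc1-c1ccc(OC)cc1`, which gives 52%.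

Compound 2 stands highest of the three in this assay, and its distance to both compound 1 and compound 3 lies beyond the usual scatter of this read-out. How the core of compound 2 differs from that of compound 1 is not broken down here. Between compound 1 and compound 3 the change is methoxy in place of hydrogen on an aromatic carbon, and the step it made was a number 2 percentage points lower from compound 1 to compound 3 (within the scatter), so the two values stand within the scatter of each other and no order between them can be read.

Compound 4, `C=CCn1c(SCC(=O)Nc2ccc(/C(C)=N/O)cc2)nnc1-c1cc(OC)c(OC)c(OC)c1`, is not yet measured. It differs from compound 2 by methoxy in place of hydrogen on an aromatic carbon, the same kind of change as from compound 1 to compound 3, but at a different place: in compound 3 the entering group sits para to a large group, whereas in compound 4 it sits ortho to a methoxy group, meta to a large group and meta to a methoxy group. A step of about a number 2 percentage points lower from compound 2 to compound 4 (within the scatter) is expected, resting on the earlier step of a number 2 percentage points lower from compound 1 to compound 3 (within the scatter), which was within the scatter. Compound 4 is therefore estimated at 68% in this assay, with a likely range from 55% to 80%.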

Compound 4, a percentage reported as inhibition, in the whole organism at one dose (the size of the read-out at that dose, not a potency): 62%
The estimate for compound 4 lay 6 percentage points above the measured number, and the stated range covers the measured number.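

In this assay, methoxy in place of hydrogen on an aromatic carbon gave a number 8 percentage points lower from compound 2 to compound 4 (within the scatter), which adds a second case to the earlier a number 2 percentage points lower from compound 1 to compound 3 (within the scatter). Set side by side, the two steps cannot be told apart, so in this small set the change carried from one core to the other without a detectable difference: the same change on two cores in this assay, a number 2 percentage points lower (within the scatter) from compound 1 to compound 3 and a number 8 percentage points lower (within the scatter) from compound 2 to compound 4, 6 percentage points apart, within the scatter of two such steps. For the compounds shown here, this does not show that the change is neutral in general or that its size is the same on every core, as it rests on only two pairs, read at a single dose, with the methoxy entering at a different place on the ring in each pair, and neither step stands clear of the scatter.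

The compounds shown leave open how a group other than methoxy, such as an amine or a carboxylic acid, would read on the same aromatic carbon, and whether a longer chain in place of the methoxy would leave the reading where it stands. They also leave open whether the methoxy change would hold on a core other than the two seen here.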